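Aryl swap on the shared core: compound 1 to compound 3

A few compounds are considered here, and "the series" means these few. Any claim that something is new, unique, unknown or untested is made for them only; others in the source may bear on it.

Measured so far:
compound 1 `C/C(=C\CC/C(C)=C/CC[C@@H]1[C@@]2(C)CCC(=O)C(C)(C)[C@H]2CC[C@@]1(C)O)CC/C=C(\C)C(=O)OCc1cn(-c2ccccc2C)nn1`: > 150000 nM
compound 2 `C/C(=C\CC/C(C)=C/CC[C@@H]1[C@@]2(C)CCC(=O)C(C)(C)[C@H]2CC[C@@]1(C)O)CC/C=C(\C)C(=O)OCc1cn(C[C@@H]2O[C@H](n3ccc(=O)[nH]c3=O)[C@H]3OC(C)(C)O[C@H]32)nn1`: > 150000 nM

In a functional assay on DU-145 cells (Homo sapiens) for antiproliferative activity, read by MTT assay, with a stated time of 48 h (a higher number here means a weaker inhibitor, a lower number a stronger inhibitor), compound 1 gives > 150000 nM, which is a limit of the assay and not a number. In this assay compound 2 likewise gives > 150000 nM, again only a limit. Both values coincide with the limit of > 150000 nM in this assay, at which 2 of the 2 values shown sit, so compound 1 stands nowhere on a scale of numbers; it is simply not active down to where the assay stops, and compound 2 gives no point of reference either.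

Compound 3 is `C/C(=C\CC/C(C)=C/CC[C@@H]1[C@@]2(C)CCC(=O)C(C)(C)[C@H]2CC[C@@]1(C)O)CC/C=C(\C)C(=O)OCc1cn(-c2cccc(Cl)c2)nn1`. Against compound 1 the change is 3-chlorophenyl in place of 2-methylphenyl on an aromatic nitrogen. Among the compounds with values here, no step between two measured compounds exists, so there is no measured size of step to lean on. Given that compound 1 sits at the limit of > 150000 nM in this assay, at which 2 of the 2 values shown sit, the change in this assay is expected to be a number no higher from compound 1 to compound 3 (the limit leaves the size open), none beyond the scatter. The estimate for compound 3 in this assay is 150000 nM, between 50000 nM and 400000 nM, with the most likely outcome that the assay again reports only a limit.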

Compound 3, half-maximal inhibitory concentration: 103000 nM
Compound 3: middle estimate off by 1.5-fold (0.16 log units), on the high side; measured number inside the range.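

In this assay, within the data shown here, compound 3 gives 103000 nM, the first true number and a reference point that the earlier compounds could not supply. Going by these compounds, with 3-chlorophenyl in place of 2-methylphenyl on an aromatic nitrogen, the record reads an at least 1.4-fold lower number from compound 1 to compound 3 (0.16 log units; that floor lies within the scatter), so only a floor for this step is known, and its real size remains open. Compound 1 still offers a limit and not a number, and the series as a whole still rests largely on such limits: the limit of > 150000 nM in this assay, at which 2 of the 3 values shown sit.

The swap alters both the substituent and the place it occupies on the phenyl ring, so the shown compounds cannot separate the contribution of the chlorine from that of its place; 2-chlorophenyl, 3-methylphenyl or plain phenyl on the same nitrogen would each address part of this. On these data alone, it also remains open whether an aryl group carrying an amine or a carboxylic acid would give a number clearly apart from that of compound 3, and a number for any such compound would be needed to size a step at this position.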